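The source may report more compounds than this note shows. Statements on the series, on what has been measured and on what is new or still open speak of the compounds shown alone.

Working notes on the series in a functional assay on A549 cells (Homo sapiens) for cytotoxicity, read by MTT assay, with a stated time of 48 h; a higher number here means a weaker inhibitor, a lower number a stronger inhibitor. Compound 1 `COc1ccc(/C=C/c2cc(OC)c(OC)c(OC)c2-c2ccc3ccccc3c2)cc1` gives 14000 nM. Compound 2 `COc1ccc(/C=C/c2cc(OC)c(OC)c(OC)c2-c2ccc(Cl)cc2)cc1` gives 30000 nM. The two differ by 4-chlorophenyl in place of naphthalen-2-yl on an aromatic carbon, and the step is a 2.1-fold higher number from compound 1 to compound 2 (0.33 log units; beyond the scatter). Compound 3 `C=C(c1ccc(OC)cc1)c1cc(OC)c(OC)c(OC)c1-c1ccc2ccccc2c1` gives 15000 nM; its core differs from the core of compound 1 by 1-(4-methoxyphenyl)ethenyl in place of 2-(4-methoxyphenyl)ethenyl on an aromatic carbon, and the step of a 1.1-fold higher number from compound 1 to compound 3 (0.03 log units; within the scatter) leaves the two values within the scatter of each other.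

Compound 4 `C=C(c1ccc(OC)cc1)c1cc(OC)c(OC)c(OC)c1-c1ccc(Cl)cc1` has not yet been measured in this assay. It differs from compound 3 by 4-chlorophenyl in place of naphthalen-2-yl on an aromatic carbon. Among the compounds shown this change occurs two times in all, once from compound 1 to compound 2 and once from compound 3 to compound 4. The surroundings of the place are not word for word the same: in the first pair the place is ortho to a 2-(4-methoxyphenyl)ethenyl group, in the second it is ortho to a 1-(4-methoxyphenyl)ethenyl group, so the change is the same kind of change, not the same.

Set beside a 2.1-fold higher number from compound 1 to compound 2 (0.33 log units; beyond the scatter), the step expected in this assay is a 2.0-fold higher number from compound 3 to compound 4 (0.30 log units; within the scatter), because a 1.1-fold higher number from compound 1 to compound 3 (0.03 log units; within the scatter) puts compound 1 and compound 3 within the scatter of each other, so the only measured instance of the change is taken as the guide. Compound 4 is therefore estimated at 30000 nM, with the expected range running from 15000 nM to 65000 nM.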

Compound 4, half-maximal inhibitory concentration: 29000 nM
For compound 4 the middle estimate is 1.0-fold (0.01 log units) above the measured one; measured number inside the range.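

In this assay, 4-chlorophenyl in place of naphthalen-2-yl on the core carrying the 1-(4-methoxyphenyl)ethenyl group gives a 1.9-fold higher number from compound 3 to compound 4 (0.29 log units; within the scatter), so this step taken alone cannot be separated from assay noise. Set beside the earlier instance, the change behaves alike on the two cores, and no difference between the two steps can be read: the same change on two cores in this assay, a 2.1-fold higher number (0.33 log units; beyond the scatter) from compound 1 to compound 2 and a 1.9-fold higher number (0.29 log units; within the scatter) from compound 3 to compound 4, 1.1-fold (0.04 log units) apart, within the scatter of two such steps

This supports carrying the change between these two cores only, which differ solely in 2-(4-methoxyphenyl)ethenyl against 1-(4-methoxyphenyl)ethenyl; it does not show that the step would hold on a core that differs in any other way, and it gives no reason for the size of the step.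

The compounds shown leave open how the series reads when the place on the aromatic carbon holds something other than these two aryl groups, such as an amine, a carboxylic acid or a longer alkyl chain. They also leave open whether the same step survives when one of the methoxy groups on the shared core gives way to a hydroxy group or an ethoxy group.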